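The source may report more compounds than this note shows. Statements on the series, on what has been measured and on what is new or still open speak of the compounds shown alone.

Of the compounds shown here, three built on a shared core have been tested in an ADME assay on PA-1 cells (Homo sapiens) for cytotoxicity, read by MTT assay, with a stated time of 72 h; on this read-out lower numbers stand for stronger inhibition and higher numbers for weaker inhibition. Compound 1 `COc1ccc(C2=C(c3cc(OC)c(OC)c(OC)c3)C(=O)C(OC(C)=O)C2)cc1F` carries a fluoro group on one of its aromatic rings; in this assay compound 1 reaches only the limit of > 100 ug/mL. Compound 2 `COc1ccc(C2=C(c3cc(OC)c(OC)c(OC)c3)C(=O)C(OC(C)=O)C2)cc1Cl` has chloro in place of fluoro on an aromatic carbon; in this assay compound 2 likewise reaches only the limit of > 100 ug/mL. Compound 3 `COc1ccc(C2=C(c3cc(OC)c(OC)c(OC)c3)CC(O)C2=O)cc1[N+](=O)[O-]` differs more widely in its core; in this assay compound 3 also gives only the limit of > 100 ug/mL. Among the measured compounds shown here, the one single-point step, a step that the two limits leave unreadable from compound 1 to compound 2, cannot be sized, because every value shown sits at the limit of > 100 ug/mL in this assay, at which 3 of the 3 values shown sit. For the measured compounds named here, compound 2 thus stands at a limit, not at a number, and no compound here has a readable value.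

Compound 4 `COc1ccc(C2=C(c3cc(OC)c(OC)c(OC)c3)C(=O)C(OC(C)=O)C2)cc1O` is the next compound in this series. The change from compound 2 to compound 4 is hydroxy in place of chloro on an aromatic carbon. Going by the values given here, no measured step bears on it in a readable way, so no direction can be drawn from the data. The expectation is therefore that compound 4 stays where the others stand: its estimated value is 150 ug/mL, with a range from 60 ug/mL to 400 ug/mL. The expected step that the limit leaves unreadable from compound 2 to compound 4 is none beyond the scatter, and a limit rather than a number is the likely outcome.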

Compound 4, half-maximal inhibitory concentration: 6 ug/mL
The estimate for compound 4 lay 25-fold (1.40 log units) above the measured number; the measured number lies below the stated range.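

Among the compounds shown here, the position ortho to a methoxy group clearly matters in this assay: with hydroxy there, compound 4 gives 6 ug/mL, the first readable number. Hydroxy in place of chloro gives an at least 16-fold lower number from compound 2 to compound 4 (1.22 log units; beyond the scatter), and hydroxy in place of fluoro gives an at least 16-fold lower number from compound 1 to compound 4 (1.22 log units; beyond the scatter), so both changes are large and lie beyond the scatter, while the steps among the limit values cannot be read. Hydroxy also brings a hydrogen-bond donor and acceptor where chloro has neither, and this single-atom change separates compound 4 from the other compounds, which all stay at a limit: the limit of > 100 ug/mL in this assay, at which 3 of the 4 values shown sit.

Going by these compounds, it remains open whether the hydrogen-bond donor and acceptor count behind the drop in this number, or whether some other feature of the hydroxy group does, and an amine at the same position would be one way to probe this. For the compounds shown here, with only one readable value, it is also unclear how far the result depends on the rest of compound 4, including the acetate on the shared core.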